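Chloro on the benzyl ring of a dihydropyrimidine amide

The compounds below may be only part of what the source reports. "The series", "measured", "known", "first", "only" and "open" are said of these compounds alone.

Three compounds from one series were tested in a functional assay on the whole organism (artery, strain albino) with Rattus norvegicus as the target, with a stated time of 240 min, at a dose of 10 mg/kg by the oral route; on this read-out lower numbers stand for less inhibition and higher numbers for more inhibition at the one dose given (going by the name of the read-out). Compound 1 `COc1ccc(C2N=C(SCc3ccc(Cl)cc3)NC(C)=C2C(=O)Nc2ccc(F)cc2)cc1OC` gives 24.1%, compound 2 `CC1=C(C(=O)Nc2ccc(Br)cc2)C(c2ccc(Cl)cc2Cl)N=C(SCc2ccccc2)N1` gives 17.4%, and compound 3 `CC1=C(C(=O)Nc2ccc([N+](=O)[O-])cc2)C(c2ccc(Br)cc2)N=C(SCc2ccccc2)N1` gives 27.7%. Compound 3 holds the highest of the three numbers, but compound 1 sits within the scatter of it, while compound 2 lies beyond the scatter below it. No pair of these compounds differs in just one place, so no single step has yet been measured. Compound 4 `CC1=C(C(=O)Nc2ccc([N+](=O)[O-])cc2)C(c2ccc(Br)cc2)N=C(SCc2ccccc2Cl)N1` differs from compound 3 only by chloro in place of hydrogen on an aromatic carbon. With nothing to guide the direction, no step beyond the scatter is expected in this assay. Compound 4 is estimated at 28%, in a range from 15% to 42%, meaning an expected step of a number 0.3 percentage points higher from compound 3 to compound 4 (within the scatter).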

Compound 4, a percentage reported as inhibition, in the whole organism at one dose (the size of the read-out at that dose, not a potency): 15.4%
For compound 4 the middle estimate is 12.6 percentage points above the measured one; the range from low to high includes it.
By their numbers in this assay, from the lowest: compounds 4, 2, 1 and 3 (each within the scatter of the next, the first and the last beyond it).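

In this assay, the first single change measured in this series, chloro in place of hydrogen on the benzyl ring, ortho to a large group, gives a number 12.3 percentage points lower from compound 3 to compound 4 (beyond the scatter), so this place on the ring is not indifferent to substitution. A single added heavy atom is enough to produce a step of this size. Nothing at hand explains the drop.

On these data alone, whether an amine or a hydroxyl group in the same place would lower the number as well remains open. So does whether chloro would have the same effect with a different amide ring or aryl group on the shared core.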